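The source may report more compounds than this note shows. Statements on the series, on what has been measured and on what is new or still open speak of the compounds shown alone.

Measured so far in a functional assay on HCT-116 cells (Homo sapiens) for antiproliferative activity, read by MTT assay, with a stated time of 72 h; a higher number here means a weaker inhibitor, a lower number a stronger inhibitor:
- Compound 1 `CCNC(=O)CCc1cccc2c1B(O)OC2`: > 100000 nM, a limit and not a number
- Compound 2 `O=C(CCc1cccc2c1B(O)OC2)Nc1nccs1`: > 100000 nM, a limit and not a number
- Compound 3 `O=C(CCc1cccc2c1B(O)OC2)Nc1cccc(Br)c1`: 1400 nM

Compound 3 is the only one of the three with a true number, 1400 nM. Compound 4 `O=C(CCc1cccc2c1B(O)OC2)Nc1cccc(-c2ccccc2)c1` changes one group of compound 3: phenyl in place of bromo on an aromatic carbon. Among the measured compounds shown here, no measured step touches the bromo itself. The nearest evidence comes from the group on the amide nitrogen: an at least 71-fold lower number from compound 1 to compound 3 (1.85 log units; beyond the scatter) and an at least 71-fold lower number from compound 2 to compound 3 (1.85 log units; beyond the scatter). Both steps are large, so this part of the molecule can matter greatly, but they give no direction for this swap. A modest step in this assay is therefore expected, with only a slight lean towards a lower number. The estimated step is a 1.4-fold lower number from compound 3 to compound 4 (0.15 log units; within the scatter). For compound 4 the estimated value is 1000 nM, with an expected range of 250 nM to 5000 nM.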

Compound 4, half-maximal inhibitory concentration: 890 nM
Beside the measured number, compound 4's estimate is 1.1-fold (0.05 log units) above it, and the stated range covers the measured number.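

In this assay putting phenyl in place of bromo gives a 1.6-fold lower number from compound 3 to compound 4 (0.20 log units; within the scatter) and so the two compounds cannot be told apart. The earlier steps shown here changed only the group on the amide nitrogen, whereas this one shows that an aromatic carbon meta to a large group can carry either 1 heavy atom or 6 with no readable difference. Nothing shown here bears on why the two groups read alike. The compounds shown leave open how an amine or a carboxylic acid on this carbon would read.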